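Swapping a Methyl for Phenyl on an Amide Carbonyl

A few compounds are considered here, and "the series" means these few. Any claim that something is new, unique, unknown or untested is made for them only; others in the source may bear on it.

Of the compounds shown here, two have been measured in an assay on isolated protein for inhibition of Nitric oxide synthase, inducible (Homo sapiens), with a stated time of 30 min, tested at 1 mM; a higher number here means more inhibition at the concentration tested (going by the name of the read-out), a lower number less inhibition. Compound 1 `COc1ccc(N)c(C2=NN(C(=O)c3ccccc3)CC2)c1` gives 12.2%, and compound 2 `CC(=O)N1CCC(c2ccccc2N)=N1` gives 7.73%. The two numbers lie within the usual scatter of each other, so compound 2 cannot be placed apart from compound 1 on these data. Compound 3 `Nc1ccccc1C1=NN(C(=O)c2ccccc2)CC1` differs from compound 2 by one change, (phenyl in place of methyl on a carbonyl carbon). Within the data shown here, no measured pair isolates this change. Because compound 2 gives 7.73% and compound 1 gives 12.2%, both small, the step of a number 2.3 percentage points higher from compound 2 to compound 3 (within the scatter) is expected to stay within the scatter. Compound 3 is estimated to give 10% in this assay, between 0% and 25%.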

Compound 3, a percentage reported as inhibition, at one concentration (the size of the read-out at that concentration, not a potency): 8.7%
Compound 3: middle estimate off by 1.3 percentage points, on the high side; low and high end bracket the measured number.
By their numbers in this assay, from the lowest: compounds 2, 3 and 1 (each within the scatter of the next).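

Among these compounds, the step of a number 1 percentage points higher from compound 2 to compound 3 (within the scatter) in this assay gives the first measured pair for phenyl in place of methyl on a carbonyl carbon, and at this place the swap does not separate the two compounds. The step of a number 3.5 percentage points lower from compound 1 to compound 3 (within the scatter) likewise shows that hydrogen in place of methoxy on an aromatic carbon does not separate that pair. Nothing available explains these results.

Going by these compounds, whether any group on this carbonyl carbon can give clearly more inhibition remains open. An amine or a longer carbon chain there would be a further test.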